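Aryl change on the shared core: compound 3 to compound 4

This account rests on a few compounds, and the source may have more. Where it says the series, first, only, none or still open, it means among the compounds named here.

Going by the values given here, in a functional assay on HeLa cells (Homo sapiens) for inhibition, read by MTT assay, with a stated time of 48 h (a higher number here means a weaker inhibitor, a lower number a stronger inhibitor), three aryl variants of the shared core have numbers so far. Compound 1 `O=C(CC(c1ccc(F)cc1)C(C(=O)Nc1ccccn1)C(=O)Nc1ccccn1)c1ccccc1` gives 20800 nM, compound 2 `O=C(CC(c1ccc([N+](=O)[O-])cc1)C(C(=O)Nc1ccccn1)C(=O)Nc1ccccn1)c1ccccc1` gives 30000 nM and compound 3 `O=C(CC(c1ccc(Cl)cc1Cl)C(C(=O)Nc1ccccn1)C(=O)Nc1ccccn1)c1ccccc1` gives 13500 nM. Compound 3 is separated on one side only: the data show a 2.2-fold lower number from compound 2 to compound 3 (0.35 log units; beyond the scatter), while they also show a 1.5-fold lower number from compound 1 to compound 3 (0.19 log units; within the scatter).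

Compound 4 `COc1ccc(C(CC(=O)c2ccccc2)C(C(=O)Nc2ccccn2)C(=O)Nc2ccccn2)cc1` is the next variant, and its change is 4-methoxyphenyl in place of 2,4-dichlorophenyl on a saturated chain carbon bound to two saturated chain carbons. In words, this is 4-methoxyphenyl in place of 2,4-dichlorophenyl on a saturated chain carbon bound to two saturated chain carbons. Among the compounds with values here, no measured compound carries the 4-methoxyphenyl group, so the only guide is the set of aryl swaps at this same carbon. Those swaps are small: the data give a 1.4-fold higher number from compound 1 to compound 2 (0.16 log units; within the scatter), and the largest of the three remains a 2.2-fold lower number from compound 2 to compound 3 (0.35 log units; beyond the scatter).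

A step of similar or smaller size is therefore expected in this assay, probably toward a higher number and probably not beyond the scatter. The expected step is a 1.5-fold higher number from compound 3 to compound 4 (0.17 log units; within the scatter). Compound 4 is estimated at 20000 nM, with an expected range of 10000 nM to 40000 nM.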

Compound 4, half-maximal inhibitory concentration: "not active" (no number reported)
Nothing numeric was reported for compound 4; no gap can be computed for the estimate.
By their numbers in this assay, from the lowest: compounds 3, 1 and 2 (each within the scatter of the next, the first and the last beyond it).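

In this assay, going by these compounds alone, compound 4 is reported as "not active" (no number reported), so no step linking it to compound 3, or to compound 1 or compound 2, can be read. The compounds shown leave open how far compound 4 lies from compound 3 on a numeric scale. No other data shown bear on this result.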